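This account rests on a few compounds, and the source may have more. Where it says the series, first, only, none or still open, it means among the compounds named here.

Compound 2 `CCC(=O)N1CCC(CN(C2Cc3cc(C#N)ccc3N(Cc3cncn3C)C2)S(=O)(=O)c2ccccn2)CC1` is one of three compounds of a shared core that have been tested in an ADME assay on Caco-2 cells (Homo sapiens) for permeability, in the apical to basolateral direction (a higher number here means that the compound crosses the layer faster, a lower number that the compound crosses the layer more slowly), where compound 2 gives 0.5 10^-6 cm/s. Compound 1 `Cn1cncc1CN1CC(N(CC2CCN(C(=O)C(C)(C)C)CC2)S(=O)(=O)c2ccccn2)Cc2cc(C#N)ccc21` gives 0.5 10^-6 cm/s in this assay, and the step shows no change at the digits printed from compound 1 to compound 2 (within the scatter), so the two stand level and together at the top of the three numbers. Compound 3 `Cn1cncc1CN1CC(N(CC2CCN(S(C)(=O)=O)CC2)S(=O)(=O)c2ccccn2)Cc2cc(C#N)ccc21` gives 0.1 10^-6 cm/s in this assay; here the step shows a 5.0-fold lower number from compound 2 to compound 3 (0.70 log units; beyond the scatter), and the parallel step from the other acyl compound shows a 5.0-fold lower number from compound 1 to compound 3 (0.70 log units; beyond the scatter).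

Compound 4 `Cn1cncc1CN1CC(N(CC2CCN(C(=O)N3CCCCC3)CC2)S(=O)(=O)c2ccccn2)Cc2cc(C#N)ccc21` differs from compound 2 in one place: piperidin-1-yl in place of ethyl on a carbonyl carbon. Among the measured compounds shown here, the measured step that bears most directly on this is the one in which the group on the same carbonyl carbon was exchanged, no change at the digits printed from compound 1 to compound 2 (within the scatter), a change of acyl size that left the number where it was. The two steps that did move the number, a 5.0-fold lower number from compound 2 to compound 3 (0.70 log units; beyond the scatter) and a 5.0-fold lower number from compound 1 to compound 3 (0.70 log units; beyond the scatter), both removed the carbonyl altogether in favour of methylsulfonyl, which the step to compound 4 does not do. Compound 4 is therefore expected to sit close to compound 2, with no change at the digits printed from compound 2 to compound 4 (within the scatter) as the expected step. The estimate for compound 4 in this assay is 0.5 10^-6 cm/s, within a range from 0.2 10^-6 cm/s to 1.2 10^-6 cm/s.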

Compound 4, apparent permeability: 0.6 10^-6 cm/s
Estimate against measurement, compound 4: 1.2-fold (0.08 log units) below; the measured number falls inside the stated range.
By their numbers in this assay, from the lowest: compound 3; then compounds 1, 2 and 4 (each within the scatter of the next).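

With piperidin-1-yl on the carbonyl carbon, the number in this assay stays within the scatter of the values for the two smaller groups (a 1.2-fold higher number from compound 2 to compound 4 (0.08 log units; within the scatter); a 1.2-fold higher number from compound 1 to compound 4 (0.08 log units; within the scatter)), so ethyl, tert-butyl and a group bearing a six-membered non-aromatic ring can all occupy this place without a step beyond the scatter. The gap to the methylsulfonyl compound also holds for this third carbonyl compound (a 6.0-fold higher number from compound 3 to compound 4 (0.78 log units; beyond the scatter)), which leaves compound 3 as the only one of the four set apart and compounds 1, 2 and 4, each with a carbonyl on the amine nitrogen in the ring, together as a group. Nothing among the data shown accounts for either the level stretch or the gap to compound 3.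

On these data alone, it remains open whether a group of another kind on this carbonyl carbon, such as a carboxylic acid or an aminomethyl chain, would also leave the number in place. As far as these compounds go, it is equally open whether a larger sulfonyl, such as phenylsulfonyl, would stay near compound 3 (0.1 10^-6 cm/s) or move towards the carbonyl compounds.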